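This account rests on a few compounds, and the source may have more. Where it says the series, first, only, none or still open, it means among the compounds named here.

Measured so far:
- compound 1 `CC(C)(C)CC#Cc1cc2ncnc(Nc3ccc(OCc4cccc(F)c4)c(Cl)c3)c2s1`: > 50 uM (a limit)
- compound 2 `CCCN(CC#Cc1cc2ncnc(Nc3ccc(OCc4cccc(F)c4)c(Cl)c3)c2s1)CCC`: > 50 uM (a limit)

In an ADME assay on NIH3T3 cells (Mus musculus) for cytotoxicity (a higher number here means that more compound is tolerated, a lower number that less compound is tolerated), compound 2 gives > 50 uM, which is a limit and not a number. The next structure, compound 3 `CC(C)CC#Cc1cc2ncnc(Nc3ccc(OCc4cccc(F)c4)c(Cl)c3)c2s1`, differs from it as follows: isopropyl in place of dipropylamino on a saturated chain carbon bound to a triple-bonded carbon. Isopropyl thus takes the place of dipropylamino on a saturated chain carbon bound to a triple-bonded carbon.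

Within the data shown here, the only measured step bearing on this change is a step that the two limits leave unreadable from compound 1 to compound 2, and it has no readable size. Both compounds sit at the same limit: the limit of > 50 uM in this assay, at which 2 of the 2 values shown sit. Compound 1 carries tert-butyl at this place, so it offers the closest comparison. No step beyond the scatter and no direction are expected in this assay. The expected change is a step that the limit leaves unreadable from compound 2 to compound 3. For compound 3 the estimated value is 55 uM, with an expected range of 25 uM to 100 uM.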

Compound 3, half-maximal toxic concentration: > 50 uM
Compound 3: only a limit was reported; the forecaster's own chance of this, stated with the estimate: 75%; the middle value is on the limit's open side.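

No step can be read among compound 1, compound 2 and compound 3 in this assay, as all three values are limits: the limit of > 50 uM in this assay, at which 3 of the 3 values shown sit.

The compounds shown leave open at what concentration any of them becomes toxic, and whether the group on the saturated chain carbon bound to a triple-bonded carbon changes that concentration.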